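Chloro to methyl on the sulfonyl aryl ring

The compounds below may be only part of what the source reports. "The series", "measured", "known", "first", "only" and "open" are said of these compounds alone.

Two members of this series carry a read-out in a functional assay on DU-145 cells (Homo sapiens) for inhibition, read by trypan blue exclusion, with a stated time of 72 h; on this read-out higher numbers stand for weaker inhibition and lower numbers for stronger inhibition. Compound 1 `Cc1ccc(S(=O)(=O)c2cc3cnc(Nc4ccc5cc[nH]c5c4)nc3n(C)c2=O)cc1` gives 15000 nM in this assay. For the measured compounds named here, compound 2 `Cn1c(=O)c(S(=O)(=O)c2ccc(Cl)cc2)cc2cnc(Nc3cccc4[nH]ccc34)nc21` gives 5000 nM in this assay, the lowest of the two numbers; the gap to compound 1 lies beyond the scatter, but the two structures differ in more than one place, so no single step can be drawn from them. Compound 3 `Cc1ccc(S(=O)(=O)c2cc3cnc(Nc4cccc5[nH]ccc45)nc3n(C)c2=O)cc1` is not yet measured. It differs from compound 2 in one place: methyl in place of chloro on an aromatic carbon. Going by the values given here, no measured pair isolates this change, so its size is open. Given the weaker read-out of compound 1, which also carries methyl at that position, a small step toward weaker inhibition, not clearly beyond the scatter, is expected from compound 2 to compound 3, a 1.6-fold higher number from compound 2 to compound 3 (0.20 log units; within the scatter). Compound 3 is estimated at 8000 nM in this assay, with a range from 3000 nM to 25000 nM.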

Compound 3, half-maximal inhibitory concentration: 10000 nM
Estimate against measurement, compound 3: 1.3-fold (0.10 log units) below; low and high end bracket the measured number.
By their numbers in this assay, from the lowest: compounds 2, 3 and 1 (each within the scatter of the next, the first and the last beyond it).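

In this assay, the exchange of chloro for methyl on the aromatic carbon para to a large group gives a 2.0-fold higher number from compound 2 to compound 3 (0.30 log units; within the scatter), so this position does not separate the two groups beyond the scatter. The exchange of 1H-indol-6-yl for 1H-indol-4-yl on the nitrogen gives a 1.5-fold lower number from compound 1 to compound 3 (0.18 log units; within the scatter), so neither single change shown here stands beyond the scatter on its own. No supporting data bear on the reason for either step.

From the compounds shown here alone, whether a group of another kind at this position, such as an amine, a carboxylic acid or a longer chain, would move the number beyond the scatter remains open. Also open is whether the two exchanges act independently, since the series shown holds no compound pairing 1H-indol-6-yl with 4-chlorophenyl.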